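From phenyl to iodo on the shared core

A few compounds are considered here, and "the series" means these few. Any claim that something is new, unique, unknown or untested is made for them only; others in the source may bear on it.

Values in a functional assay on CCRF-CEM cells (Homo sapiens), read by MTT assay, with a stated time of 72 h; a higher number here means a weaker inhibitor, a lower number a stronger inhibitor:
- compound 1 `Cc1nc(N)c2c(-c3ccoc3)cn([C@@H]3O[C@H](CO)[C@@H](O)[C@H]3O)c2n1`: > 100000 nM (a limit)
- compound 2 `Cc1nc(N)c2c(-c3cccs3)cn([C@@H]3O[C@H](CO)[C@@H](O)[C@H]3O)c2n1`: > 20000 nM (a limit)
- compound 3 `Cc1nc(N)c2c(-c3ccccc3)cn([C@@H]3O[C@H](CO)[C@@H](O)[C@H]3O)c2n1`: > 20000 nM (a limit)

Compound 3 has no number, only a limit, and it rests on (the limit of > 20000 nM in this assay, at which 2 of the 3 values shown sit). Compound 1 rests on a separate limit, (the limit of > 100000 nM in this assay, at which 1 of the 3 values shown sits).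

The next change gives compound 4 `Cc1nc(N)c2c(I)cn([C@@H]3O[C@H](CO)[C@@H](O)[C@H]3O)c2n1`, with iodo in place of phenyl on an aromatic carbon.

The nearest evidence is a step that the two limits leave unreadable from compound 1 to compound 3 and a step that the two limits leave unreadable from compound 2 to compound 3, along with a step that the two limits leave unreadable from compound 1 to compound 2. For the measured compounds named here, none of these has a readable size, and no iodo compound has been measured. Compound 4 is therefore expected to stay weak in this assay, with only a tentative lean towards a lower number.

The estimated step is an at least 1.3-fold lower number from compound 3 to compound 4 (0.12 log units; that floor lies within the scatter).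

For compound 4 the estimate is 15000 nM, with an expected range from 2000 nM to 100000 nM.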

Compound 4, half-maximal inhibitory concentration: 9030 nM
Compound 4: the middle estimate sits 1.7-fold (0.22 log units) above what was measured; measured number inside the range.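

In this assay, for the compounds shown here, compound 4 is the first to give a number rather than a limit, which shows that this position can carry a measurable effect. Iodo, with no ring, gives an at least 2.2-fold lower number from compound 3 to compound 4 (0.34 log units; beyond the scatter), an at least 2.2-fold lower number from compound 2 to compound 4 (0.34 log units; beyond the scatter) and an at least 11-fold lower number from compound 1 to compound 4 (1.04 log units; beyond the scatter). Each step starts from a limit, so each size is a floor.

Compound 4 is the only non-ring group shown, so it stays open whether the change depends on losing the ring or on iodine itself. Bromo, chloro or methyl at this place would separate the two.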